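The compounds below may be only part of what the source reports. "The series", "measured", "known", "first", "only" and "open" are said of these compounds alone.

The series is a small one. Compound 1 `CC(C)(C)OC(=O)NCCCNC(=O)CN1CN(c2ccccc2)C2(CCN(C(=O)c3ccc(C4CCCCC4)cc3)CC2)C1=O` and compound 2 `CCC1CCCN(C(=O)CN2CN(c3ccccc3)C3(CCN(C(=O)c4ccc(C5CCCCC5)cc4)CC3)C2=O)C1` share a common core and differ only in the group attached to one carbonyl carbon. In an assay on HEK293 cells for displacement of a labelled ligand from NPC1-like intracellular cholesterol transporter 1 (Homo sapiens) (on this read-out higher numbers stand for weaker inhibition and lower numbers for stronger inhibition), compound 1 gives 6000 nM, while compound 2 gives 2600 nM. For the measured compounds named here, the change a 2.3-fold lower number from compound 1 to compound 2 (0.36 log units; beyond the scatter) is the only measured step in the set, and it leaves compound 2 with the lower of the two numbers, compound 1 being its sole neighbour.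

Compound 3 `CC1(C)CC(OC(=O)CN2CN(c3ccccc3)C3(CCN(C(=O)c4ccc(C5CCCCC5)cc4)CC3)C2=O)CC(C)(C)N1` continues from compound 2 by a single change: (2,2,6,6-tetramethylpiperidin-4-yl)oxy in place of 3-ethylpiperidin-1-yl on a carbonyl carbon. Going by the values given here, the one step that bears on it, a 2.3-fold lower number from compound 1 to compound 2 (0.36 log units; beyond the scatter), also altered the substituent on that same carbonyl carbon and was modest in size. Among the compounds with values here, the present change is of a different kind, and nothing among the measured compounds shows how such a group behaves in this assay. A step of no more than modest size is therefore expected, with the direction uncertain. Compound 3 is estimated at 4000 nM in this assay, within a range of 1500 nM to 12000 nM, which corresponds to an expected 1.5-fold higher number from compound 2 to compound 3 (0.19 log units; within the scatter).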

Compound 3, half-maximal inhibitory concentration: 600 nM
Estimate against measurement, compound 3: 6.7-fold (0.82 log units) above, and the stated range ends above it.
By their numbers in this assay, from the lowest: compound 3; then compound 2; then compound 1.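

In this assay, the substituent on this carbonyl carbon proves able to shift the number further than the first step showed: (2,2,6,6-tetramethylpiperidin-4-yl)oxy in place of 3-ethylpiperidin-1-yl gives a 4.3-fold lower number from compound 2 to compound 3 (0.64 log units; beyond the scatter), and in place of (3-((tert-butoxycarbonyl)amino)propyl)amino it gives a 10-fold lower number from compound 1 to compound 3 (1.00 log units; beyond the scatter). Compound 3 is also the only one of the three whose group is joined to the carbonyl carbon through oxygen rather than nitrogen, so this position accepts that exchange, and compound 3 has the lowest number of the series, with both of its steps beyond the scatter. Nothing available here accounts for the drop in the number.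

The change replaced the linking atom and the ring together, so the compounds shown leave open how much of the step belongs to each. A (2,2,6,6-tetramethylpiperidin-4-yl)amino group on the same carbonyl carbon would test the oxygen link, while a plain piperidin-4-yloxy group would test the methyl groups on the ring.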